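The source may hold more compounds than are shown below. What is called first, only, known or untested is meant among the compounds shown, and "the series" means these compounds.

Three compounds built on one shared core differ only in the aromatic ring carried on an amine nitrogen in a ring. Compound 1 `O=C1c2ccccc2S(=O)(=O)N1CCCCCCN1CCN(c2ccc(Cl)c(Cl)c2)CC1` carries 3,4-dichlorophenyl there, compound 2 `O=C1c2ccccc2S(=O)(=O)N1CCCCCCN1CCN(c2ccccc2C(F)(F)F)CC1` carries 2-(trifluoromethyl)phenyl, and compound 3 `O=C1c2ccccc2S(=O)(=O)N1CCCCCCN1CCN(c2ccccc2)CC1` carries plain phenyl. In an ADME assay on HEK293 cells for displacement of a labelled ligand from 5-hydroxytryptamine receptor 6 (Homo sapiens), read by radioligand binding, with a stated time of 1 h (a lower number here means a stronger inhibitor, a higher number a weaker inhibitor), compound 1 gives 132 nM, compound 2 gives 1270 nM, and compound 3 gives 971 nM. Compound 3 therefore stands second highest of the three numbers, sitting close to one of them with a 1.3-fold lower number from compound 2 to compound 3 (0.12 log units; within the scatter) and well apart from the other with a 7.4-fold higher number from compound 1 to compound 3 (0.87 log units; beyond the scatter).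

Compound 4 `O=C1c2ccccc2S(=O)(=O)N1CCCCCCN1CCN(c2ccccn2)CC1` is compound 3 with one change: pyridin-2-yl in place of phenyl on an amine nitrogen in a ring. Within the data shown here, no measured step swaps a ring carbon for a ring nitrogen, so none bears on it directly. The two steps that end at compound 3 show that replacing trifluoromethyl by hydrogen, a 1.3-fold lower number from compound 2 to compound 3 (0.12 log units; within the scatter), left the number where it was, whereas giving up both chlorine atoms, a 7.4-fold higher number from compound 1 to compound 3 (0.87 log units; beyond the scatter), raised it modestly. A change that adds no large group to the ring is therefore expected to move this assay little, and the estimated step is a 1.4-fold higher number from compound 3 to compound 4 (0.16 log units; within the scatter). Compound 4 is accordingly expected to give about 1400 nM, within a range from 450 nM to 4500 nM.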

Compound 4, inhibition constant: 2350 nM
Compound 4: middle estimate off by 1.7-fold (0.22 log units), on the low side, within the range that was stated.
By their numbers in this assay, from the lowest: compound 1; then compounds 3, 2 and 4 (each within the scatter of the next, the first and the last beyond it).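

Among these compounds, replacing one ring carbon with a ring nitrogen, in a group on an amine nitrogen in a ring, is not a silent change in this assay and gives a modest step beyond the scatter (a 2.4-fold higher number from compound 3 to compound 4 (0.38 log units; beyond the scatter)), so this position responds even when no large group is added, which the earlier compounds did not show. The pyridin-2-yl and 2-(trifluoromethyl)phenyl groups cannot be told apart here (a 1.9-fold higher number from compound 2 to compound 4 (0.27 log units; within the scatter)), while the 3,4-dichlorophenyl group of compound 1 remains the strongest of the four, now by the widest gap seen at this position (an 18-fold higher number from compound 1 to compound 4 (1.25 log units; beyond the scatter)). Nothing available explains why this swap of one ring atom shifts the number.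

On these data alone, it remains open whether the position of the ring nitrogen matters, as pyridin-3-yl and pyridin-4-yl would test. Also open is whether a single chlorine or a methoxy group on the phenyl ring would recover part of what the 3,4-dichlorophenyl group achieves, and whether a shorter chain to the shared core would keep the same order among these groups.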